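Cytotoxicity Outlook for a Phenylpropyl Amide Variant

The source may hold more compounds than are shown below. What is called first, only, known or untested is meant among the compounds shown, and "the series" means these compounds.

Compound 1 `COc1ccc2nc(C)cc(OCC(=O)Nc3cccc(Br)c3)c2c1` was tested in an ADME assay on HepG2 cells (Homo sapiens) for cytotoxicity, read by trypan blue exclusion, with a stated time of 48 h, in the presence of a further agent that is not named here; a lower number here means that less compound is tolerated, a higher number that more compound is tolerated. In this assay compound 1 gives only a limit, > 125000 nM, and not a number. Compound 2 `COc1ccc2nc(C)cc(OCC(=O)Nc3ccc(-c4ccccc4)cc3)c2c1` also reaches only a limit in this assay, > 126000 nM. Compound 1 therefore stands at a limit rather than at a measured value (the limit of > 125000 nM in this assay, at which 1 of the 2 values shown sits). Compound 2 stands at a limit as well (the limit of > 126000 nM in this assay, at which 1 of the 2 values shown sits). Compound 3 `COc1ccc2nc(C)cc(OCC(=O)NCCCc3ccccc3)c2c1` differs from compound 1 in one place: 3-phenylpropyl in place of 3-bromophenyl on an amide-type nitrogen. No step between two measured compounds exists here, and both readings shown are limits, so nothing points to a change beyond the usual scatter in this assay. The step from compound 1 to compound 3 in this assay is expected to be a number no higher from compound 1 to compound 3 (the limit leaves the size open), no real movement. For compound 3 the expected value in this assay is 125000 nM, with a range from 60000 nM to 250000 nM.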

Compound 3, half-maximal cytotoxic concentration: 50700 nM
Compound 3: the middle estimate sits 2.5-fold (0.39 log units) above what was measured, and the stated range ends above it.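

On the amide-type nitrogen, whose other neighbour is the carbonyl carbon, the group is not silent in this assay and the change from 3-bromophenyl to 3-phenylpropyl gives an at least 2.4-fold lower number from compound 1 to compound 3 (0.39 log units; beyond the scatter) as its step. Within the data shown here, this is the first sign that this position can move the read-out beyond the scatter, and compound 3 gives a true number where the earlier readings gave none. The step has only a lower bound because its starting point is a limit and not a number: the limit of > 125000 nM in this assay, at which 1 of the 3 values shown sits.

The compounds shown leave open whether the drop follows from the added chain, the lost bromine or both. A benzyl or 2-phenylethyl group on the same nitrogen, or a 3-(3-bromophenyl)propyl group there, would help to separate these.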